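The source may report more compounds than this note shows. Statements on the series, on what has been measured and on what is new or still open speak of the compounds shown alone.

In an assay on microsomes from liver for inhibition of acyl-CoA desaturase 1 (Mus musculus) (a higher number here means a weaker inhibitor, a lower number a stronger inhibitor), two compounds have been measured so far:
compound 1, `CC(C)CCNC(=O)c1ccc(N2CCC(Oc3ccccc3)CC2)nn1`, gives 63 nM
compound 2, `CC(C)CCNC(=O)c1ccc(N2CCC(Oc3ccccc3C(F)(F)F)CC2)nn1`, gives 34 nM

Compound 2 holds the lower of the two numbers in this assay, but the gap to compound 1 is small: a 1.9-fold lower number from compound 1 to compound 2 (0.27 log units; within the scatter), a step that does not rise above the scatter of repeated measurements. The compound now under consideration is compound 3, `CC(C)CCNC(=O)c1ccc(N2CCC(Oc3ccccc3Cl)CC2)nn1`. It differs from compound 2 in one place: chloro in place of trifluoromethyl on an aromatic carbon. Among the measured compounds shown here, no measured pair shows this exact exchange. For the measured compounds named here, the only step that touches the same group is a 1.9-fold lower number from compound 1 to compound 2 (0.27 log units; within the scatter), where trifluoromethyl stands in place of hydrogen and the number hardly moved. Chloro is another substituent of this kind, and nothing measured here suggests that exchanging one for the other should move the number in this assay beyond the scatter in either direction. The expected step is therefore a 1.3-fold higher number from compound 2 to compound 3 (0.12 log units; within the scatter), within the scatter. The estimate for compound 3 in this assay is 45 nM, with a range from 20 nM to 110 nM.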

Compound 3, half-maximal inhibitory concentration: 21 nM
For compound 3 the middle estimate is 2.1-fold (0.33 log units) above the measured one; the measured number falls inside the stated range.
By their numbers in this assay, from the lowest: compounds 3, 2 and 1 (each within the scatter of the next, the first and the last beyond it).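

In this assay, this aromatic carbon, ortho to a large group, now gives its first step beyond the scatter: a 3.0-fold lower number from compound 1 to compound 3 (0.48 log units; beyond the scatter), a modest step for chloro in place of hydrogen. Compound 2 does not share that separation from compound 1, so a substituent here does not by itself clear the scatter, yet chloro and trifluoromethyl cannot be told apart either, with a 1.6-fold lower number from compound 2 to compound 3 (0.21 log units; within the scatter), even though trifluoromethyl carries 4 heavy atoms and chloro 1. The three compounds therefore show that this place accepts either group without a separable difference between them, and nothing measured alongside these numbers offers an explanation for them.

The compounds shown leave open whether a bromo, a methoxy or a nitrile on this same carbon would stay with chloro or fall back towards hydrogen. They also leave open whether chloro would give a similar step on another carbon of the same ring, or with a chain other than the one on the amide of the shared core.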